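This account rests on a few compounds, and the source may have more. Where it says the series, first, only, none or still open, it means among the compounds named here.

In a physicochemical assay for solubility, measured as kinetic solubility (on this read-out lower numbers stand for lower solubility and higher numbers for higher solubility), compound 1 (`CNC(=O)c1cc(C(=O)N[C@H]2CC[C@H](O)CC2)c([C@@H](C)c2cccc(Cl)c2)o1`) gives >= 179 ug/mL, which is a limit of the assay and not a number. Compound 2 (`CNC(=O)c1cc(C(=O)N[C@H]2CC[C@H](O)CC2)n([C@@H](C)c2cccc(C(F)(F)F)c2)n1`) gives 7 ug/mL, so compound 1 stands at the high end of the two readings.

Compound 3 (`CNC(=O)c1cc(C(=O)N[C@H]2CC[C@H](O)CC2)c([C@@H](C)c2ccc(C)cc2)o1`) follows from compound 1 by one change: 4-methylphenyl in place of 3-chlorophenyl on a saturated chain carbon bound to an aromatic carbon and a saturated chain carbon. This places 4-methylphenyl in place of 3-chlorophenyl on a saturated chain carbon bound to an aromatic carbon and a saturated chain carbon, and the rest of the structure stays the same.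

For the measured compounds named here, no measured step covers this change, so the expectation rests on the reading for compound 1 alone. The expected step, an at least 1.3-fold lower number from compound 1 to compound 3 (0.13 log units; that floor lies within the scatter), is a slight fall that stays within the usual scatter. Compound 3 is estimated at 130 ug/mL, with an expected range of 40 ug/mL to 250 ug/mL.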

Compound 3, solubility: >= 245 ug/mL
Compound 3: no number, only a limit; the forecaster's own chance of this, stated with the estimate: 40%; at least 1.8-fold (0.27 log units) between middle value and limit.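

In this assay, for the compounds shown here, compound 1 and compound 3 both stand as limits of the assay and not as numbers, so no step between them can be read. The compounds shown leave open whether 4-methylphenyl in place of 3-chlorophenyl changes the reading in this assay at all, and in which direction.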